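The compounds below may be only part of what the source reports. "The series", "measured", "known", "first", "only" and "open" are said of these compounds alone.

Of the compounds shown here, three built on a nucleoside scaffold have been tested in a functional assay on CEM-DNR-bulk cells (Homo sapiens), read by MTT assay, with a stated time of 72 h; a higher number here means a weaker inhibitor, a lower number a stronger inhibitor. Compound 1 `Cc1nc(N)c2c(-c3ccco3)cn([C@@H]3O[C@H](CO)[C@@H](O)[C@H]3O)c2n1` carries a furan-2-yl group on its core. In this assay compound 1 gives > 20000 nM, which is a limit of the assay rather than a number. Compound 3 `Cc1nc(N)c2c(-c3ccoc3)cn([C@@H]3O[C@H](CO)[C@@H](O)[C@H]3O)c2n1` differs from compound 1 in one place: furan-2-yl in place of furan-3-yl on an aromatic carbon. In this assay compound 3 gives > 20000 nM, again a limit. The step that the two limits leave unreadable from compound 3 to compound 1 is unreadable, with both ends at the limit of > 20000 nM in this assay, at which 3 of the 3 values shown sit. Compound 2 `COc1nc(N)nc2c1c(-c1ccoc1)cn2[C@@H]1O[C@H](CO)[C@@H](O)[C@H]1O` has a different core; how the core of compound 2 differs from that of compound 3 is not broken down here. In this assay compound 2 gives > 20000 nM, also a limit. All three measured values share (the limit of > 20000 nM in this assay, at which 3 of the 3 values shown sit), so no ordering among them can be drawn.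

Compound 4 `COc1nc(N)nc2c1c(-c1ccco1)cn2[C@@H]1O[C@H](CO)[C@@H](O)[C@H]1O` has not yet been measured. It is related to compound 2 by the same change that leads from compound 3 to compound 1: furan-2-yl in place of furan-3-yl on an aromatic carbon. Among the compounds with values here, the only guide is the step from compound 3 to compound 1, whose size is not readable. The step from compound 2 to compound 4 is therefore expected to be a step that the limit leaves unreadable from compound 2 to compound 4, with considerable uncertainty. That expectation rests on compound 3 and compound 1 both sitting at the limit of > 20000 nM in this assay, at which 3 of the 3 values shown sit. In this assay compound 4 is estimated at 30000 nM, most likely again reported only as a limit, with a range from 8000 nM to 120000 nM.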

Compound 4, half-maximal inhibitory concentration: > 20000 nM
Compound 4: no number, only a limit (the forecaster's own chance of this, stated with the estimate: 85%); the middle value lies beyond the limit too.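

In this assay compound 4 gives > 20000 nM, which is a limit of the assay and not a number. The step from compound 2 to compound 4, furan-2-yl in place of furan-3-yl, therefore cannot be read: the limit of > 20000 nM in this assay, at which 4 of the 4 values shown sit. The compounds shown leave open whether furan-2-yl and furan-3-yl differ at all in this assay and what change would give a measurable value there.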